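Swapping formyl for methoxy on the sulfonyl aryl ring

The source may report more compounds than this note shows. Statements on the series, on what has been measured and on what is new or still open speak of the compounds shown alone.

Compound 1, `COC(=O)c1cc(=O)c2c(OC)cc(OC)cc2n1C`, in a functional assay on KOPN-8 cells (Homo sapiens) for antiproliferative activity, with a stated time of 72 h (on this read-out higher numbers stand for an effect only at larger amounts of compound and lower numbers for an effect already at smaller amounts), gives > 19000 nM, which is a limit of the assay and not a number.
Compound 2, `COC(=O)c1cc(=O)c2c(OC)cc(OC)cc2n1S(=O)(=O)c1ccc(C)cc1`, gives 6000 nM in this assay.
Compound 3, `COc1ccc(-c2cc(=O)c3c(OC)cc(OC)cc3n2S(=O)(=O)c2ccc(C=O)cc2)cc1`, gives > 34400 nM in this assay, again a limit rather than a number.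

So compound 3 stands at a limit, as does one of the other values shown, and only compound 2 has a measured number. Compound 4, `COc1ccc(-c2cc(=O)c3c(OC)cc(OC)cc3n2S(=O)(=O)c2ccc(OC)cc2)cc1`, is the unmeasured relative of compound 3. The change is methoxy in place of formyl on an aromatic carbon. Within the data shown here, with no measured pair to lean on, the step of an at least 2.2-fold lower number from compound 3 to compound 4 (0.36 log units; beyond the scatter) is my expectation, leaning toward a smaller number but with wide uncertainty. For compound 4 I estimate 15000 nM, between 3000 nM and 60000 nM, and a limit is quite possible.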

Compound 4, half-maximal effective concentration: > 82700 nM
Compound 4 ended at the assay's limit; the forecaster's own chance of this, stated with the estimate: 55%; at least 5.5-fold (0.74 log units) between middle value and limit.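

Compound 3 and compound 4 both sit at limits rather than at numbers, and the step between them cannot be read. Going by these compounds, whether methoxy in place of formyl changes the read-out at all stays open.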